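The source may hold more compounds than are shown below. What is called first, only, known or untested is meant among the compounds shown, and "the series" means these compounds.

Measured compounds in an assay on SH-EP1 cells for displacement of a labelled ligand from Neuronal acetylcholine receptor; alpha4/beta2 (Homo sapiens), read by scintillation counting; on this read-out lower numbers stand for stronger inhibition and higher numbers for weaker inhibition: compound 1 `CC(C)C(=O)N1CC2CC(C1)N2` gives 130 nM; compound 2 `O=C(C1CC=CC1)N1CC2CC(C1)N2` gives 51 nM; compound 3 `O=C([C@H]1C[C@H]1F)N1CC2CC(C1)N2` gives 1.1 nM.

Compound 3 stands lowest of the three numbers in this assay. Its nearest neighbour is compound 2, whose value lies well above it, and compound 1 lies further off still. Within the data shown here, the one measured step that reaches compound 3 is a 120-fold lower number from compound 1 to compound 3 (2.07 log units; beyond the scatter), a large move on the amide substituent of the shared core.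

Compound 4 `C[C@@H]1C[C@@H]1C(=O)N1CC2CC(C1)N2` is not yet measured. Against compound 3 the change is methyl in place of fluoro on a saturated ring carbon. Among the measured compounds shown here, no measured pair shows the exchange of fluoro for methyl on this three-membered ring, so the step from compound 1 to compound 3 bears only indirectly: it shows that the fluorinated three-membered ring carries the strongest binding seen, and offers no reading of how much of that rests on the fluorine rather than on the ring itself. Compound 2, with a five-membered ring on the carbonyl, gives a far higher number than compound 3, which marks the three-membered ring as the favourable element. A modest upward step is therefore expected, a 3.6-fold higher number from compound 3 to compound 4 (0.56 log units; beyond the scatter), with compound 4 estimated at 4 nM in this assay, range 0.8 nM to 20 nM.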

Compound 4, inhibition constant: 22 nM
For compound 4 the middle estimate is 5.5-fold (0.74 log units) below the measured one, and the stated range ends below it.
By their numbers in this assay, from the lowest: compound 3; then compound 4; then compound 2; then compound 1.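

In this assay, the exchange of fluoro for methyl on a saturated ring carbon gives a 20-fold higher number from compound 3 to compound 4 (1.30 log units; beyond the scatter) and shows that the number at this position depends strongly on the substituent, not on the three-membered ring alone. The methyl-bearing ring still gives a 5.9-fold lower number from compound 1 to compound 4 (0.77 log units; beyond the scatter) against the isopropyl amide, so only a modest part of the larger gain seen with compound 3 remains once the fluoro group has left. No supporting measurement accounts for the size of the fluoro-to-methyl step.

The compounds shown leave open where the unsubstituted cyclopropyl group would stand, and so how much the fluoro and methyl groups each add to or take from the bare ring. From the compounds shown here alone, how a hydroxyl, chloro or nitrile group would read on this ring carbon also remains open.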